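This account rests on a few compounds, and the source may have more. Where it says the series, first, only, none or still open, it means among the compounds named here.

Measured compounds:
compound 1 `COc1ncnc2c1ncn2[C@@H]1O[C@H](COC(C)=O)[C@@H](OC(C)=O)[C@@H]1OC(C)=O` — in a physicochemical assay for metabolic stability, at pH 7 (a higher number here means that the compound lasts longer, a lower number that the compound disappears faster), compound 1 gives 365 h
compound 2 `CCC(=O)OC[C@H]1O[C@@H](n2cnc3c(OC)ncnc32)[C@@H](OC(=O)CC)[C@@H]1OC(=O)CC` — compound 2 gives 3050 h
compound 3 `COc1ncnc2c1ncn2[C@@H]1O[C@H](CO)[C@@H](OC(C)=O)[C@@H]1OC(C)=O` — compound 3 gives 458 h

Compound 2 stands highest of the three in this assay: its gaps to compound 3 and to compound 1 both lie beyond the scatter, so it is the longest-lasting compound measured here. Compound 4 `CCC(=O)O[C@H]1[C@H](OC(=O)CC)[C@@H](CO)O[C@H]1n1cnc2c(OC)ncnc21` differs from compound 2 in one place: hydrogen in place of propanoyl on an oxygen on a saturated carbon.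

For the measured compounds named here, one measured step bears on this change. Between compound 1 and compound 3 an acetyl was exchanged for hydrogen on an oxygen on a saturated carbon, and the result was a 1.3-fold higher number from compound 1 to compound 3 (0.10 log units; within the scatter). The present change removes a propanoyl rather than an acetyl from the same kind of position, and the three-carbon acyl groups of compound 2 otherwise remain. On that single precedent, no step beyond the scatter is expected in this assay for compound 4, with at most a slight drift upward.

Compound 4 is therefore estimated at 3500 h, with a range from 1500 h to 8000 h. The expected step is a 1.1-fold higher number from compound 2 to compound 4 (0.06 log units; within the scatter).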

Compound 4, half-life: 12600 h
For compound 4 the middle estimate is 3.6-fold (0.56 log units) below the measured one; the whole stated range lies below it.
By their numbers in this assay, from the lowest: compounds 1 and 3 (each within the scatter of the next); then compound 2; then compound 4.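

In this assay, hydrogen in place of propanoyl on an oxygen on a saturated carbon gives a 4.1-fold higher number from compound 2 to compound 4 (0.62 log units; beyond the scatter), so in the compounds carrying propanoyl groups this change moves the number upward by more than the scatter. The matching exchange of acetyl for hydrogen, a 1.3-fold higher number from compound 1 to compound 3 (0.10 log units; within the scatter), stays within the scatter, so on these two pairs alone the size of the step differs with the acyl groups the compound carries. No measurement given here accounts for that difference.

As far as these compounds go, whether the step would continue with a longer chain such as butanoyl in the remaining ester places stays open. So does whether an amine or a carboxylic acid in place of the hydroxymethyl would keep the number of compound 4.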